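A few compounds are considered here, and "the series" means these few. Any claim that something is new, unique, unknown or untested is made for them only; others in the source may bear on it.

Measured so far:
- Compound 1 `COc1cc(C2=NN(C(C)=O)C(c3ccccc3C(F)(F)F)O2)cc(OC)c1OC`: 31.8%
- Compound 2 `COc1cccc(/C=N/NC(=O)c2cc(OC)c(OC)c(OC)c2)c1OC`: -0.1%
- Compound 3 `COc1cc(C(=O)N/N=C/c2ccc(Cl)c(Cl)c2)cc(OC)c1OC`: 29.6%

In a functional assay on BGC-823 cells (Homo sapiens) for antiproliferative activity, read by MTT assay, tested at 1 uM (a higher number here means a stronger effect of the compound at the concentration tested, a lower number a weaker effect), compound 1 gives the top number of the three shown, yet compound 3 lies within the usual scatter of it, so the two cannot be told apart; compound 2 sits far below. Compound 4 `COc1cc(C2=NN(C(C)=O)C(c3ccc(Cl)c([N+](=O)[O-])c3)O2)cc(OC)c1OC` is the next compound and differs from compound 1 in one place only: 4-chloro-3-nitrophenyl in place of 2-(trifluoromethyl)phenyl on a saturated ring carbon. Going by the values given here, no two measured compounds differ in a single place, so no measured step exists to lean on. Among the compounds with values here, with only this single-point change on the saturated ring carbon, the step from compound 1 to compound 4 is expected to be small, a number 1.8 percentage points lower from compound 1 to compound 4 (within the scatter), with no clear direction beyond the scatter. Compound 4 is therefore estimated at 30%, within a range from 12% to 48%.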

Compound 4, a percentage reported as inhibition, at one concentration (the size of the read-out at that concentration, not a potency): -2.3%
Beside the measured number, compound 4's estimate is 32.3 percentage points above it; the measured number lies below the stated range.
By their numbers in this assay, from the lowest: compounds 4 and 2 (each within the scatter of the next); then compounds 3 and 1 (each within the scatter of the next).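

On the saturated ring carbon, 4-chloro-3-nitrophenyl in place of 2-(trifluoromethyl)phenyl gives a number 34.1 percentage points lower from compound 1 to compound 4 (beyond the scatter) in this assay. This position is therefore not indifferent: with the rest of the molecule unchanged, the group here decides whether any effect remains. No measurement at hand explains the loss.

The compounds shown leave open whether the chlorine, the nitro group or the absence of trifluoromethyl matters most. A phenyl carrying only a chlorine, only a nitro group, or an amine would help separate these possibilities.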